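Working notes: fluoro on compound 2

A few compounds are considered here, and "the series" means these few. Any claim that something is new, unique, unknown or untested is made for them only; others in the source may bear on it.

Among the compounds with values here, in a functional assay on MDA-MB-231 cells (Homo sapiens) for antiproliferative activity, read by MTT assay, with a stated time of 24 h (on this read-out lower numbers stand for stronger inhibition and higher numbers for weaker inhibition), compound 2 (`O=C(O)CC(NS(=O)(=O)c1cc(F)cc(F)c1)c1ccccc1`) gives 79300 nM, the only true number in the set so far. Compound 1 (`O=C(O)CC(NC(=O)c1cccc(Br)c1)c1ccccc1`) gives > 100000 nM, which is a limit of the assay. Compound 3 (`O=C(O)CC(NC(=O)c1cccc(Br)c1)c1ccccc1F`) gives > 100000 nM, again a limit. The reading of the series is therefore bounded by the limit of > 100000 nM in this assay, at which 2 of the 3 values shown sit.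

Compound 4 (`O=C(O)CC(NS(=O)(=O)c1cc(F)cc(F)c1)c1ccccc1F`) departs from compound 2 by one change: fluoro in place of hydrogen on an aromatic carbon. Within the data shown here, the one measured step with the same replacement, phenyl to 2-fluorophenyl, is a step that the two limits leave unreadable from compound 1 to compound 3, so it offers no size to carry over. Without a readable precedent, no shift in either direction is expected in this assay beyond the usual scatter. The estimated change is a 1.0-fold higher number from compound 2 to compound 4 (0.00 log units; within the scatter). For compound 4 the expected value is 80000 nM, with an estimated range of 35000 nM to 120000 nM. A result reported only as a limit would not be surprising.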

Compound 4, half-maximal inhibitory concentration: 73500 nM
The estimate for compound 4 lay 1.1-fold (0.04 log units) above the measured number; the range from low to high includes it.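

Phenyl to 2-fluorophenyl now has a readable size in this assay, on the sulfonamide compounds, with a 1.1-fold lower number from compound 2 to compound 4 (0.03 log units; within the scatter). The step between the amide compounds cannot be read, so this single pair carries all that is known of fluoro at this place, ortho to a large group, and it shows no change beyond the scatter. The reading of the series remains tied to the assay limit: the limit of > 100000 nM in this assay, at which 2 of the 4 values shown sit.

Still open, as far as these compounds go, is whether another group at this place, such as an amine, a methoxy group or chlorine, would move the number beyond the scatter. Also open, from the compounds shown here alone, is whether a primary amide in place of the carboxylic acid would shift the values of the sulfonamide compounds.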